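Compound 1 Without Its 2,5-Dioxopyrrolidin-3-yl Group

A few compounds are considered here, and "the series" means these few. Any claim that something is new, unique, unknown or untested is made for them only; others in the source may bear on it.

In a functional assay on U-373MG ATCC cells (Homo sapiens) for cytotoxicity, read by MTT assay, with a stated time of 72 h (on this read-out lower numbers stand for stronger inhibition and higher numbers for weaker inhibition), compound 1 `COc1ccc2[nH]c(-c3ccc[nH]3)c(C3CC(=O)NC3=O)c2c1` gives 15000 nM. This is the higher of the two exact numbers available, the other being compound 3 `O=C1CC(c2c(-c3ccc[nH]3)[nH]c3ccccc23)C(=O)N1` at 4000 nM. Compound 2 `c1ccc2[nH]c(-n3cccn3)cc2c1` carries no 2,5-dioxopyrrolidin-3-yl group and differs from compound 1 in other ways too. Compound 2 gives > 100000 nM, and this value is a limit rather than an exact number.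

Compound 4 `COc1ccc2[nH]c(-c3ccc[nH]3)cc2c1` differs from compound 1 in one place: hydrogen in place of 2,5-dioxopyrrolidin-3-yl on an aromatic carbon. In words, this is hydrogen in place of 2,5-dioxopyrrolidin-3-yl on an aromatic carbon, two ring bonds from the ring nitrogen.

Going by the values given here, only one measured step changes a single place, and it swaps hydrogen for methoxy elsewhere on the molecule, giving a 3.8-fold lower number from compound 1 to compound 3 (0.57 log units; beyond the scatter). Among the compounds with values here, that modest step shows how much one small change can move the number, but no measured step removes the 2,5-dioxopyrrolidin-3-yl group itself. The direction therefore rests on compound 2 alone, so a move towards a higher number, meaning weaker inhibition, is expected with wide uncertainty.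

The expected change is a 3.3-fold higher number from compound 1 to compound 4 (0.52 log units; beyond the scatter).

Compound 4 is estimated at 50000 nM, with an expected range from 15000 nM to 100000 nM.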

Compound 4, half-maximal inhibitory concentration: 43000 nM
For compound 4 the middle estimate is 1.2-fold (0.07 log units) above the measured one, within the range that was stated.
By their numbers in this assay, from the lowest: compound 3; then compound 1; then compound 4. At a limit, above all of these: compound 2.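

In this assay, going by these compounds alone, taking away the 2,5-dioxopyrrolidin-3-yl group and leaving only hydrogen on that aromatic carbon gives a 2.9-fold higher number from compound 1 to compound 4 (0.46 log units; beyond the scatter), the first measured step at this place. Within this one pair, the presence of the group goes with stronger inhibition, but the step is modest, and compound 4 still gives an exact number, so a measurable effect on these cells does not depend on the group. Compound 2 differs from compound 1 in several ways and its value is a limit, not a number, so it provides no step for this change: the limit of > 100000 nM in this assay, at which 1 of the 4 values shown sits.

The compounds shown leave open which part of the 2,5-dioxopyrrolidin-3-yl group matters, and whether a simpler group on the same carbon, such as an amine, a carboxylic acid or an open-chain amide, would give a number closer to that of compound 1 or of compound 4. They also leave open whether removing the group would have a similar effect on compound 3, which carries hydrogen in place of the methoxy group.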